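This account rests on a few compounds, and the source may have more. Where it says the series, first, only, none or still open, it means among the compounds named here.

The series shares the core of compound 1 `CSC[C@H](NC(=O)c1ccc(C#Cc2ccccc2)cc1)C(=O)NO`, which in a physicochemical assay for lipophilicity (on this read-out lower numbers stand for lower lipophilicity and higher numbers for higher lipophilicity), gives 3. Compound 2 `O=C(C[C@H](NC(=O)c1ccc(C#Cc2ccccc2)cc1)C(=O)NO)NCCCO` gives 2 in this assay, and compound 3 `NC[C@H](NC(=O)c1ccc(C#Cc2ccccc2)cc1)C(=O)NO` gives 2 in this assay. Compound 3 stands level with compound 2, the two together the lowest of the three numbers: the step of no change at the digits printed from compound 2 to compound 3 (within the scatter) lies within the scatter, while a number 1.00 log units lower from compound 1 to compound 3 (beyond the scatter) and a number 1.00 log units lower from compound 1 to compound 2 (beyond the scatter) both lie beyond it.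

Within the data shown here, the next step leads to compound 4 `CS(=O)(=O)C[C@H](NC(=O)c1ccc(C#Cc2ccccc2)cc1)C(=O)NO`. methylsulfonyl in place of amino on a saturated chain carbon, two bonds along the chain from an amide-type nitrogen and a carbonyl carbon No measured step has methylsulfonyl on either side, so none bears directly on this change. The two steps that touch the same chain carbon, a number 1.00 log units lower from compound 1 to compound 2 (beyond the scatter) and a number 1.00 log units lower from compound 1 to compound 3 (beyond the scatter), both start from methylsulfanyl and run in the same direction by the same amount, and no change at the digits printed from compound 2 to compound 3 (within the scatter) shows the two entering groups of those steps level with each other. On that basis only a small step is expected in this assay, its direction uncertain. The estimated step is a number 0.40 log units lower from compound 3 to compound 4 (beyond the scatter). For compound 4 the expected value in this assay is 1.6, with a range from 0.9 to 2.3.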

Compound 4, distribution coefficient: 2
The estimate for compound 4 lay 0.40 log units below the measured number; low and high end bracket the measured number.
By their numbers in this assay, from the lowest: compounds 2, 3 and 4 (each within the scatter of the next); then compound 1.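

At the saturated chain carbon, methylsulfonyl sits level with both earlier replacements in this assay, with no change at the digits printed from compound 3 to compound 4 (within the scatter) and no change at the digits printed from compound 2 to compound 4 (within the scatter). Replacing methylsulfanyl with methylsulfonyl gives a number 1.00 log units lower from compound 1 to compound 4 (beyond the scatter), the same size as the two earlier steps away from methylsulfanyl, so a sulfur in the entering group does not keep the number at the level of compound 1, and compound 1 alone stands apart among the four. Nothing measured here gives a reason for this shared level.

The compounds shown leave open whether a carboxylic acid, a tertiary amine or a longer sulfanyl chain such as ethylsulfanyl on this carbon would join the level of compounds 2, 3 and 4 or that of compound 1. They also leave open whether methylsulfinyl, which holds one oxygen on the sulfur, would fall with methylsulfanyl or with methylsulfonyl.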